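The compounds below may be only part of what the source reports. "The series", "measured", "known", "first", "only" and "open" are said of these compounds alone.

Compound 2 `N=C(N)NCCC[C@H](NC(=O)CN(c1nc(Cl)nc2[nH]cnc12)C1CC1)C(=O)O` gives the higher of the two numbers in a functional assay on the whole organism (Tail, strain ICR) with Mus musculus as the target, in the tail flick test, with a stated time of 30 min, at a dose of 25 umol/kg by the oral route (a higher number here means a stronger effect of the compound at the dose given, a lower number a weaker effect), namely 45.4%; compound 1 `O=C(CN(c1nc(Cl)nc2[nH]cnc12)C1CC1)N[C@@H](CO)C(=O)OCc1ccccc1` in this assay gives 31.9%, a gap beyond the scatter. Going by the values given here, no pair of measured compounds differs in one place, so the change to compound 3 `O=C(CN(c1nc(Cl)nc2[nH]cnc12)C1CC1)N[C@@H](CO)C(=O)O` stands on its own: one oxygen atom in place of a group of 6 heavy atoms (3 carbon, 3 nitrogen; no ring), on a saturated chain carbon, two bonds along the chain from an amide-type nitrogen and a carbonyl carbon. A fall of modest size is expected, a number 15.4 percentage points lower from compound 2 to compound 3 (beyond the scatter), given that compound 1 also carries the hydroxy and gives 31.9% in this assay. Compound 3 is estimated at 30% in this assay, with a range from 12% to 50%.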

Compound 3, a percentage reported as activity, at one dose (the size of the read-out at that dose, not a potency): 38.7%
Beside the measured number, compound 3's estimate is 8.7 percentage points below it, within the range that was stated.
By their numbers in this assay, from the lowest: compounds 1, 3 and 2 (each within the scatter of the next, the first and the last beyond it).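

In this assay, one oxygen atom in place of the group of 6 heavy atoms, on a saturated chain carbon, gives a number 6.7 percentage points lower from compound 2 to compound 3 (within the scatter), so at this dose the read-out does not separate hydroxy from that larger group. On an oxygen next to a carbonyl group, hydrogen in place of benzyl gives a number 6.8 percentage points higher from compound 1 to compound 3 (within the scatter), so these two are not separated either. Nothing available bears on the cause of either step.

Going by these compounds, whether an amine or a longer chain on that saturated chain carbon would give a number beyond the scatter remains open. So does whether methyl in place of benzyl on that oxygen would.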